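The compounds below may be only part of what the source reports. "The series", "measured", "known", "first", "only" and "open" are said of these compounds alone.

Working notes on the series.

Three compounds have numbers in an assay on isolated protein for displacement of a labelled ligand from metabotropic glutamate receptor 5 (Homo sapiens), with a stated time of 60 min, tested at 1 uM; a lower number here means less inhibition, a higher number more inhibition at the concentration tested (going by the name of the read-out). Compound 1 `Cc1ccc(S(=O)(=O)c2cnc3ccc(Cl)cc3c2N2CCC(C)CC2)cc1` gives 95%, compound 2 `CC1CCN(c2c(S(=O)(=O)c3cc(F)cc(F)c3)cnc3ccc(Cl)cc23)CC1` gives 93%, and compound 3 `CC1CCN(c2c(S(=O)(=O)c3ccccc3)cnc3ccc(Cl)cc23)CC1` gives 59%. Compound 3 stands lowest of the three: the step of a number 34 percentage points lower from compound 2 to compound 3 (beyond the scatter) and the step of a number 36 percentage points lower from compound 1 to compound 3 (beyond the scatter) are both beyond the scatter, while a number 2 percentage points lower from compound 1 to compound 2 (within the scatter) is within it.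

Compound 4 `CC1CCN(c2c(S(=O)(=O)c3cc(Cl)cc(Cl)c3)cnc3ccc(Cl)cc23)CC1` is not yet measured. It differs from compound 3 in one place: 3,5-dichlorophenyl in place of phenyl on a sulfonyl sulfur. The step that bears on this is a number 34 percentage points lower from compound 2 to compound 3 (beyond the scatter), where the unsubstituted phenyl came in for the 3,5-difluorophenyl and the number fell by a large amount. Putting a 3,5-dichlorophenyl on the sulfonyl sulfur in place of the phenyl is the corresponding move in the other direction, with chlorine rather than fluorine, so a large increase is expected. The step of a number 36 percentage points lower from compound 1 to compound 3 (beyond the scatter) shows the same range of movement for another substitution on the shared core.

Compound 4 is therefore expected to show a number 31 percentage points higher from compound 3 to compound 4 (beyond the scatter) in this assay. The estimate for compound 4 is 90%, with a range of 74% to 98%.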

Compound 4, a percentage reported as inhibition, at one concentration (the size of the read-out at that concentration, not a potency): 88%
For compound 4 the middle estimate is 2 percentage points above the measured one; the measured number falls inside the stated range.
By their numbers in this assay, from the lowest: compound 3; then compounds 4, 2 and 1 (each within the scatter of the next).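

Going from phenyl to 3,5-dichlorophenyl on the sulfonyl sulfur gives a number 29 percentage points higher from compound 3 to compound 4 (beyond the scatter) in this assay and so the gap first seen between phenyl and 3,5-difluorophenyl recurs with chlorine in place of fluorine. The exchange of the two halogens gives a number 5 percentage points lower from compound 2 to compound 4 (within the scatter) and the change from 4-methylphenyl gives a number 7 percentage points lower from compound 1 to compound 4 (within the scatter) so compound 1, compound 2 and compound 4 cannot be told apart here, and compound 3 alone stands apart from them. No measurement is available that explains these differences.

A read-out at a single concentration is not a potency, so any real separation among compound 1, compound 2 and compound 4 remains unresolved. Also open, from the compounds shown here alone, is how the number would respond to a methoxy, a trifluoromethyl, a nitrile or a carboxylic acid on the phenyl ring.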